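This account rests on a few compounds, and the source may have more. Where it says the series, first, only, none or still open, it means among the compounds named here.

Two compounds have been measured in an ADME assay on MCF10 cells (Homo sapiens) for cytotoxicity; a higher number here means a weaker inhibitor, a lower number a stronger inhibitor:

compound 1 `CCc1nc(N)nc(N)c1C#CC(C)c1ccc(-c2ccncc2)cc1OC` — 216000 nM
compound 2 `CCc1nc(N)nc(N)c1C#CC(C)c1ccc(-c2ccc(C#N)cc2)cc1OC` — 50000 nM

Compound 2 gives the lowest of the two numbers in this assay; its nearest neighbour is compound 1, and the step of a 4.3-fold lower number from compound 1 to compound 2 (0.64 log units; beyond the scatter) came with 4-cyanophenyl in place of pyridin-4-yl on an aromatic carbon. Compound 3 `CCc1nc(N)nc(N)c1C#CC(C)c1ccc(-c2ccc(F)cc2)cc1OC` differs from compound 2 as follows: fluoro in place of cyano on an aromatic carbon. For the measured compounds named here, no measured step reproduces this exchange of fluoro for cyano on the outer ring; the one step that exists, a 4.3-fold lower number from compound 1 to compound 2 (0.64 log units; beyond the scatter), replaced the whole outer ring and is therefore only a loose guide. On that thin basis no step beyond the scatter is firmly expected, though a modest rise back toward compound 1 would not be surprising. Compound 3 is therefore estimated at 80000 nM in this assay, within a range of 30000 nM to 220000 nM, which means an expected step of a 1.6-fold higher number from compound 2 to compound 3 (0.20 log units; within the scatter).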

Compound 3, half-maximal inhibitory concentration: 60000 nM
Compound 3: middle estimate off by 1.3-fold (0.12 log units), on the high side; low and high end bracket the measured number.
By their numbers in this assay, from the lowest: compounds 2 and 3 (each within the scatter of the next); then compound 1.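

In this assay, fluoro in place of cyano, para to a large group on the outer ring, gave a 1.2-fold higher number from compound 2 to compound 3 (0.08 log units; within the scatter) and so left the two compounds within the scatter of each other, which means that the nitrile is not needed at this position to hold the number seen for compound 2. For the compounds shown here, the change from the pyridine ring to a substituted phenyl ring now shows up twice, since a 3.6-fold lower number from compound 1 to compound 3 (0.56 log units; beyond the scatter) stands alongside a 4.3-fold lower number from compound 1 to compound 2 (0.64 log units; beyond the scatter) and in both cases the step lies beyond the scatter, leaving compound 1 apart from the other two with no compound among the three going against this. No supporting measurement is available to say why the numbers fall this way.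

From the compounds shown here alone, it remains open whether an unsubstituted phenyl ring, or a phenyl ring carrying an amine, a methoxy group or a carboxylic acid at this position, would stay with compound 2 and compound 3 or move toward compound 1. Going by these compounds, it is also open whether a pyridin-3-yl ring would behave as the pyridin-4-yl ring of compound 1 does.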